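Indole enones on MCF7: the bromo to methoxy step

A few compounds are considered here, and "the series" means these few. Any claim that something is new, unique, unknown or untested is made for them only; others in the source may bear on it.

Measured in a functional assay on MCF7 cells (Homo sapiens) for cytotoxicity, read by sulforhodamine B assay, with a stated time of 48 h; on this read-out lower numbers stand for higher toxicity in this test and higher numbers for lower toxicity in this test:
Compound 1 `COc1ccc(/C(Cl)=C/C=C(\C#N)C(=O)c2c[nH]c3ccccc23)cc1`: > 100000 nM, a limit of the assay.
Compound 2 `Cc1[nH]c2ccccc2c1C(=O)/C(C#N)=C/C=C(\Cl)c1ccc(Br)cc1`: > 100000 nM, a limit of the assay.
Compound 3 `N#C/C(=C\C=C(/Cl)c1ccc(Br)cc1)C(=O)c1c[nH]c2ccc(Br)cc12`: > 100000 nM, a limit of the assay.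

Compound 3 stands only at a limit in this assay. The two further values shown are limits as well, so the limit of > 100000 nM in this assay, at which 3 of the 3 values shown sit, is all that is known of the series. Compound 4 `COc1ccc(/C(Cl)=C/C=C(\C#N)C(=O)c2c[nH]c3ccc(Br)cc23)cc1` differs from compound 3 by methoxy in place of bromo on an aromatic carbon, which cut one bond further out reads 4-bromophenyl to 4-methoxyphenyl. Compound 1 already carries that 4-methoxyphenyl and sits at the limit. Within the data shown here, no step between measured compounds is available; the expected step that the limit leaves unreadable from compound 3 to compound 4 is none beyond the scatter. Compound 4 is accordingly expected to return only a limit, estimated at 150000 nM (range 50000 nM to 500000 nM).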

Compound 4, concentration lethal to 50% of the cells: > 100000 nM
Compound 4: no number, only a limit; the forecaster's own chance of this, stated with the estimate: 85%; the middle value lies beyond the limit too.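

No step can be read from compound 3 or compound 1 to compound 4, with every value a limit: the limit of > 100000 nM in this assay, at which 4 of the 4 values shown sit. The compounds shown leave open whether methoxy in place of bromo, or bromo in place of hydrogen, changes the read-out at all.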